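Alkylamino chain length and cytotoxicity tolerance in Vero cells

This account rests on a few compounds, and the source may have more. Where it says the series, first, only, none or still open, it means among the compounds named here.

compound 1 `CCCCCCNc1nccnc1C(=O)NCc1ccccc1` — > 100000 nM
compound 2 `CCCCCCCNc1nccnc1C(=O)NCc1ccccc1` — > 100000 nM

In an ADME assay on Vero cells (Chlorocebus sabaeus) for cytotoxicity, read by microscopy, with a stated time of 6 days (a lower number here means that less compound is tolerated, a higher number that more compound is tolerated), compound 1 gives > 100000 nM, which is a limit of the assay and not a number. Compound 2 gives > 100000 nM in this assay, likewise a limit. The step that the two limits leave unreadable from compound 1 to compound 2 is therefore unreadable in size. Compound 2 stands at a limit, and the other value shown sits at the same limit (the limit of > 100000 nM in this assay, at which 2 of the 2 values shown sit).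

Compound 3 `CCCCCNc1nccnc1C(=O)NCc1ccccc1` remains to be measured in this assay. The change hydrogen in place of ethyl on a saturated chain carbon, five bonds along the chain from a nitrogen on an aromatic ring shortens the chain by one more carbon pair than the measured step removed. Within the data shown here, the only measured step that bears on it is a step that the two limits leave unreadable from compound 1 to compound 2, whose size is not readable because both values rest at the limit (the limit of > 100000 nM in this assay, at which 2 of the 2 values shown sit). No step beyond the scatter is expected from this change. Compound 3 is estimated to give 100000 nM, with a range from 50000 nM to 200000 nM. The step this estimate implies, a number no higher from compound 2 to compound 3 (the limit leaves the size open), is expected to lie within the scatter, most likely again reported only as a limit.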

Compound 3, minimum cytotoxic concentration: > 100000 nM
Compound 3: no number, only a limit; the forecaster's own chance of this, stated with the estimate: 80%; the middle value sits exactly at the limit.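

Compound 1, compound 2 and compound 3 each give only a limit in this assay, so no step among them can be read: the limit of > 100000 nM in this assay, at which 3 of the 3 values shown sit.

The compounds shown leave open what actual minimum cytotoxic concentration any of these three compounds has, and whether chain length affects it at all.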